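Adding One Methyl to a Shared Amine Nitrogen

A few compounds are considered here, and "the series" means these few. Any claim that something is new, unique, unknown or untested is made for them only; others in the source may bear on it.

Measured compounds:
- compound 1, `O=C(C1COCCN1)N1CCC2(CCN(c3nccc(NCc4ccc(Cl)cc4Cl)n3)CC2)C1`: 233 ug/mL
- compound 2, `Clc1ccc(CNc2ccnc(N3CCC4(CCN(CC5CCCN5)C4)CC3)n2)c(Cl)c1`: 270 ug/mL

Both compounds were tested in a physicochemical assay for solubility, read by chemiluminescence, measured as kinetic solubility; a lower number here means a less soluble compound, a higher number a more soluble compound. Compound 1 gives 233 ug/mL and compound 2 gives 270 ug/mL. Among the measured compounds shown here, the only step between them, a 1.2-fold higher number from compound 1 to compound 2 (0.06 log units; within the scatter), concerns the amine nitrogen in a ring and lies within the scatter, so the two numbers cannot be told apart.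

Compound 3, `CN(Cc1ccc(Cl)cc1Cl)c1ccnc(N2CCC3(CCN(CC4CCCN4)C3)CC2)n1`, has not yet been measured. It differs from compound 2 in a single place: methyl in place of hydrogen on a nitrogen on an aromatic ring. No measured step touches this nitrogen, so the shown data give no direct guide to the size or direction of the step from compound 2 to compound 3. For the measured compounds named here, the one step that is known was small, and compound 2 stands within the scatter of compound 1.

In the absence of a bearing step, compound 3 is expected to stay close to compound 2 in this assay, with an expected step of a 1.1-fold lower number from compound 2 to compound 3 (0.03 log units; within the scatter). The estimate for compound 3 is therefore 250 ug/mL, with a range from 120 ug/mL to 500 ug/mL.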

Compound 3, solubility: 141 ug/mL
For compound 3 the middle estimate is 1.8-fold (0.25 log units) above the measured one, within the range that was stated.
By their numbers in this assay, from the lowest: compounds 3, 1 and 2 (each within the scatter of the next).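

Among the compounds shown here, this is the first step that touches the nitrogen on an aromatic ring, the one whose other neighbours are an aromatic carbon and a saturated chain carbon. In this assay, methyl in place of hydrogen on this nitrogen gives a 1.9-fold lower number from compound 2 to compound 3 (0.28 log units; within the scatter) and, as that step is within the scatter, this single pair cannot tell (2,4-dichlorobenzyl)(methyl)amino apart from (2,4-dichlorobenzyl)amino. No measurement at hand offers an explanation for the number seen with this change.

The compounds shown carry only hydrogen or methyl on this nitrogen, so the numbers that an ethyl group, a longer chain or an acetyl group there would give in this assay remain open. Also open, on these data alone, is whether the same methyl would give a step of similar size in a compound carrying (morpholin-3-yl)carbonyl, the group of compound 1, instead of the (pyrrolidin-2-yl)methyl shared by compound 2 and compound 3.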